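A few compounds are considered here, and "the series" means these few. Any claim that something is new, unique, unknown or untested is made for them only; others in the source may bear on it.

Three compounds built on one shared core were tested in a functional assay on T47D cells (Homo sapiens) for cytotoxicity, read by MTT assay, with a stated time of 2 days; a higher number here means a weaker inhibitor, a lower number a stronger inhibitor. Compound 1 `Cc1ccc2c(=O)[nH]c(-c3ccccc3OC(F)(F)F)nc2c1` carries a trifluoromethoxy group; in this assay compound 1 gives only a limit, > 50000 nM. Compound 2 `Cc1ccc2c(=O)[nH]c(-c3ccccc3F)nc2c1` carries a fluoro group instead; in this assay compound 2 likewise gives only a limit, > 50000 nM. Compound 3 `Cc1ccc2nc(-c3cccc(F)c3)[nH]c(=O)c2c1` also carries a fluoro group; in this assay compound 3 again gives only a limit, > 50000 nM. Compounds 2 and 3 have the same atoms joined differently, and the difference between the two cores is not broken down here.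

The change from compound 2 to compound 1 is trifluoromethoxy in place of fluoro on an aromatic carbon. Because both values sit at the limit of > 50000 nM in this assay, at which 3 of the 3 values shown sit, the step that the two limits leave unreadable from compound 2 to compound 1 cannot be sized.

Compound 4 `Cc1ccc2nc(-c3cccc(OC(F)(F)F)c3)[nH]c(=O)c2c1` has not yet been measured. It differs from compound 3 by trifluoromethoxy in place of fluoro on an aromatic carbon. For the measured compounds named here, this is the same kind of change as the one from compound 2 to compound 1, but not the same: in compound 1 the entering group stands ortho to a large group, whereas in compound 4 it stands meta to a large group. As the earlier step has no readable size, nothing is carried over from it; the expectation rests only on the fact that every measured compound in this assay sits at the limit. The step from compound 3 to compound 4 is expected to be a step that the limit leaves unreadable from compound 3 to compound 4. Compound 4 is therefore estimated at 60000 nM, within a range from 25000 nM to 200000 nM, and it is judged most likely to give only a limit as well.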

Compound 4, half-maximal inhibitory concentration: > 50000 nM
Compound 4: only a limit was reported; the forecaster's own chance of this, stated with the estimate: 85%; the middle value does not contradict the limit.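

No step can be read between compound 3 and compound 4, nor between compound 2 and compound 1, because each pair sits at the same limit of the assay, which is not a number: the limit of > 50000 nM in this assay, at which 4 of the 4 values shown sit. The compounds shown leave open how trifluoromethoxy and fluoro compare in this assay, and whether the two cores differ there at all.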